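Sulfonamide variation in a calpain-1 inhibitor series

A few compounds are considered here, and "the series" means these few. Any claim that something is new, unique, unknown or untested is made for them only; others in the source may bear on it.

Measured so far:
compound 1: `CC(C)C[C@@H](C=O)NC(=O)[C@@H](NS(=O)(=O)c1ccc2ccccc2c1)C(C)C`, 10 nM
compound 2: `CCC[C@H](NS(=O)(=O)c1ccc(F)cc1)C(=O)N[C@H](C=O)CC(C)C`, 130 nM
compound 3: `CC(C)C[C@@H](C=O)NC(=O)[C@@H](NS(C)(=O)=O)C(C)C`, 830 nM

Three compounds have been run in an assay on isolated protein for inhibition of Calpain-1 catalytic subunit (Rattus norvegicus), read by fluorescence; on this read-out higher numbers stand for weaker inhibition and lower numbers for stronger inhibition. Compound 3 gives the highest number of the three; compound 2 gives a lower number, and compound 1 lower still, both gaps beyond the scatter. Compound 4, `CC(C)C[C@@H](C=O)NC(=O)[C@@H](NS(=O)(=O)c1ccc(Cl)cc1)C(C)C`, has not been measured. It differs from compound 3 only at the sulfonyl sulfur: 4-chlorophenyl in place of methyl on a sulfonyl sulfur. For the measured compounds named here, no directly comparable single step is available, yet the two aryl sulfonamides, compound 1 and compound 2, both sit well below compound 3. The step of a 21-fold lower number from compound 3 to compound 4 (1.32 log units; beyond the scatter) is therefore expected to be large and downward. Compound 4 is estimated at 40 nM, within 10 nM to 150 nM.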

Compound 4, half-maximal inhibitory concentration: 31 nM
For compound 4 the middle estimate is 1.3-fold (0.11 log units) above the measured one, within the range that was stated.
By their numbers in this assay, from the lowest: compound 1; then compound 4; then compound 2; then compound 3.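

In this assay the sulfonyl sulfur now has a comparison in which nothing else changes: with 4-chlorophenyl in place of methyl there is a 27-fold lower number from compound 3 to compound 4 (1.43 log units; beyond the scatter). The earlier compounds shown here could not show this, since none of them formed a single-change pair, so this position alone is now known to shift the number by a large amount. No available measurement explains the size of this step.

As far as these compounds go, it remains open whether the ring or the chlorine accounts for the step. Unsubstituted phenyl or benzyl on the sulfonyl sulfur would separate the two.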